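Benzyl substituent change at the thioether of compound 3

The compounds below may be only part of what the source reports. "The series", "measured", "known", "first", "only" and "open" are said of these compounds alone.

Among the measured compounds shown here, compound 3 `Cc1cc(S(=O)(=O)/N=C(\N)n2nccc2-c2ccccc2)c(SCc2ccc(C(F)(F)F)cc2)cc1Cl` gives 17000 nM in a functional assay on HeLa cells (Homo sapiens) for cytotoxicity, read by MTT assay, with a stated time of 72 h (on this read-out lower numbers stand for stronger inhibition and higher numbers for weaker inhibition), the second highest of the three numbers measured so far. Its nearest neighbour is compound 2 `Cc1cc(-c2ccccc2)n(/C(N)=N/S(=O)(=O)c2cc(C)c(Cl)cc2SCc2ccc(C(F)(F)F)cc2)n1`, which gives 19000 nM; the step of a 1.1-fold lower number from compound 2 to compound 3 (0.05 log units; within the scatter) lies within the scatter. The furthest is compound 1 `Cc1cc(S(=O)(=O)/N=C(\N)n2nccc2-c2ccccc2)c(SCc2ccccc2)cc1Cl`, which gives 5000 nM; the step of a 3.4-fold higher number from compound 1 to compound 3 (0.53 log units; beyond the scatter) is the only one in the set beyond the scatter.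

Compound 4 `Cc1cc(S(=O)(=O)/N=C(\N)n2nccc2-c2ccccc2)c(SCc2ccccc2C)cc1Cl` differs from compound 3 by 2-methylphenyl in place of 4-(trifluoromethyl)phenyl on a saturated chain carbon bound to a sulfur. The change has two parts: the trifluoromethyl group leaves, and a methyl arrives on the 2-methylphenyl ring. Only the first part has a measured precedent, the modest step of a 3.4-fold higher number from compound 1 to compound 3 (0.53 log units; beyond the scatter), which the removal of the trifluoromethyl reverses. For the measured compounds named here, the methyl that enters has no counterpart among the measured compounds, so its contribution cannot be read from the data. The expected direction is therefore a lower number, of a size similar to that step, with the unknown part widening the range.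

For compound 4 the expected value in this assay is 6000 nM, with a range from 2500 nM to 15000 nM. This corresponds to an expected step of a 2.8-fold lower number from compound 3 to compound 4 (0.45 log units; beyond the scatter).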

Compound 4, half-maximal inhibitory concentration: 17000 nM
Estimate against measurement, compound 4: 2.8-fold (0.45 log units) below; measured number above the stated range.
By their numbers in this assay, from the lowest: compound 1; then compounds 3, 4 and 2 (each within the scatter of the next).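

In this assay, the thioether benzyl position tolerates exchange of its substituent without any readable shift: no change at the digits printed from compound 3 to compound 4 (within the scatter), so 2-methylbenzyl and 4-(trifluoromethyl)benzyl cannot be told apart here. Measured against the unsubstituted benzyl, a single methyl on the ring gives a 3.4-fold higher number from compound 1 to compound 4 (0.53 log units; beyond the scatter), a step that matches a 3.4-fold higher number from compound 1 to compound 3 (0.53 log units; beyond the scatter), so among these three compounds the unsubstituted benzyl alone stands apart, with the lower number, and the two different substituents give the same result. The methyl-for-hydrogen exchange also does not carry over from one part of the molecule to another, since it registers on the benzyl ring but not on the other ring that carries it in compound 2 and compound 3: the same change on two cores in this assay, a 1.1-fold lower number (0.05 log units; within the scatter) from compound 2 to compound 3 and a 3.4-fold lower number (0.53 log units; beyond the scatter) from compound 4 to compound 1, 3.0-fold (0.48 log units) apart, beyond the scatter of two such steps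

The compounds shown leave open whether any substituent on the benzyl ring gives this higher number or only these two do, which a carboxylic acid or an amine on that ring would test. They also leave open whether the benzyl itself is needed at the sulfur, which a longer chain such as phenethyl in its place would address.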